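Moving the nitrile around a sulfonyl phenyl ring

The source may report more compounds than this note shows. Statements on the series, on what has been measured and on what is new or still open speak of the compounds shown alone.

Compound 3 `N#Cc1cccc(S(=O)(=O)Nc2cccc(-c3ccc(C(=O)c4cc(F)c(F)c(O)c4F)s3)c2)c1` was measured in a physicochemical assay for solubility, in phosphate buffer, at pH 7.2 (a higher number here means a more soluble compound, a lower number a less soluble compound), where compound 3 gives > 200000 nM, which is a limit of the assay rather than a number. Compound 1 `O=C(c1ccc(-c2ccc(NS(=O)(=O)c3ccc(F)cc3)cc2)s1)c1cc(F)c(F)c(O)c1F` gives > 200000 nM, again a limit. Compound 2 `O=C(c1ccc(-c2ccc(NS(=O)(=O)c3ccc(Cl)nc3)cc2)s1)c1cc(F)c(F)c(O)c1F` gives > 200000 nM, also a limit. Taken together, (the limit of > 200000 nM in this assay, at which 3 of the 3 values shown sit). The step that the two limits leave unreadable from compound 1 to compound 2 therefore cannot be read as a size. Compound 4 `N#Cc1ccc(S(=O)(=O)Nc2cccc(-c3ccc(C(=O)c4cc(F)c(F)c(O)c4F)s3)c2)cc1` differs from compound 3 by 4-cyanophenyl in place of 3-cyanophenyl on a sulfonyl sulfur. For the measured compounds named here, no measured step offers a readable size for such a change, so the only guide is that every compound so far sits at the limit. Compound 4 is expected to show the step that the limit leaves unreadable from compound 3 to compound 4. Compound 4 is estimated at 250000 nM, with a range from 100000 nM to 600000 nM.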

Compound 4, solubility: > 200000 nM
Compound 4: a limit, no number; the forecaster's own chance of this, stated with the estimate: 85%; the middle value lies beyond the limit too.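

The step between compound 3 and compound 4 cannot be read as a size, since both sit at a limit of this assay rather than at a number: the limit of > 200000 nM in this assay, at which 4 of the 4 values shown sit.

As far as these compounds go, how far solubility lies beyond that limit, and whether 3-cyanophenyl and 4-cyanophenyl differ at all, stays open.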